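This account rests on a few compounds, and the source may have more. Where it says the series, first, only, none or still open, it means among the compounds named here.

Compounds measured in an assay on isolated protein for inhibition of Monoamine oxidase (Rattus norvegicus); a higher number here means a weaker inhibitor, a lower number a stronger inhibitor:
compound 1, `C=C=C(Cc1ccccc1)CN(C)C`: > 100000 nM
compound 2, `C=C=C(CN)Cc1ccccc1`: 140 nM
compound 3, `C=C=C(CN)Cc1ccc(OC)cc1`: 580 nM

Compound 1 gives only a limit of this assay, (the limit of > 100000 nM in this assay, at which 1 of the 3 values shown sits). Among the numbers that are not limits, compound 2 stands lowest, with compound 3 nearest: a 4.1-fold higher number from compound 2 to compound 3 (0.62 log units; beyond the scatter). Compound 4, `C=C=C(CNC)Cc1ccccc1`, differs from compound 2 by methyl in place of hydrogen on an amine nitrogen. The step that bears on this is an at least 710-fold lower number from compound 1 to compound 2 (2.85 log units; beyond the scatter), where two methyls on the nitrogen were removed at once. Compound 4 carries one methyl, so a rise of intermediate size is expected, with the number staying well short of the limit seen for compound 1. The estimate for compound 4 is 600 nM, between 120 nM and 6000 nM, a step of a 4.3-fold higher number from compound 2 to compound 4 (0.63 log units; beyond the scatter).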

Compound 4, half-maximal inhibitory concentration: 440 nM
Compound 4: middle estimate off by 1.4-fold (0.13 log units), on the high side; the range from low to high includes it.
By their numbers in this assay, from the lowest: compound 2; then compounds 4 and 3 (each within the scatter of the next). At a limit, above all of these: compound 1.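

In this assay a single methyl on the amine nitrogen is already enough to move the number beyond the scatter (a 3.1-fold higher number from compound 2 to compound 4 (0.50 log units; beyond the scatter)). Compound 4 therefore separates the two methyls of compound 1, and by far the larger change comes with the second one (an at least 220-fold lower number from compound 1 to compound 4 (2.35 log units; beyond the scatter)). As far as these compounds go, that step starts from a limit of the assay, so its true size stays unknown.

From the compounds shown here alone, whether an ethyl group or a longer chain on the amine nitrogen would behave like methyl remains open, as does the effect of a methoxy group on the aromatic ring of compound 4.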